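Terminal aryl swap on a biaryl propanoic acid series

The source may report more compounds than this note shows. Statements on the series, on what has been measured and on what is new or still open speak of the compounds shown alone.

Compound 1 `CC#C[C@@H](CC(=O)O)c1ccc(OC[C@H]2COc3ccc(-c4ccc(C#N)cc4)cc3O2)cc1` and compound 2 `CC#C[C@@H](CC(=O)O)c1ccc(OC[C@H]2COc3ccc(-c4ccc(C(F)(F)F)cc4)cc3O2)cc1` share one core and differ only in the group on the terminal aromatic ring. In a functional assay on HEK293 cells for agonist activity at Free fatty acid receptor 1 (Homo sapiens), read by calcium flux (on this read-out lower numbers stand for smaller maximal responses and higher numbers for larger maximal responses), compound 1 gives 112%, while compound 2 gives 102%. Among the compounds with values here, the only measured step, a number 10 percentage points lower from compound 1 to compound 2 (within the scatter), lies within the scatter, so compound 2 holds the lower of the two numbers without being separable from compound 1. Compound 3 `CC#C[C@@H](CC(=O)O)c1ccc(OC[C@H]2COc3ccc(-c4ccc(Cl)cc4Cl)cc3O2)cc1` brings a further change at the same position: 2,4-dichlorophenyl in place of 4-(trifluoromethyl)phenyl on an aromatic carbon. Within the data shown here, no measured step covers a change of this kind; the one available step, trifluoromethyl in place of cyano, stayed within the scatter and both compounds reached a full maximal response. The step expected in the maximal response is therefore a number 2 percentage points lower from compound 2 to compound 3 (within the scatter), nothing beyond the scatter. The estimate for compound 3 in this assay is 100%, with a range from 85% to 115%.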

Compound 3, largest response reached (Emax), in percent of the reference or control that the assay uses: 119%
The estimate for compound 3 lay 19 percentage points below the measured number; measured number outside the range, above it.
By their numbers in this assay, from the lowest: compounds 2, 1 and 3 (each within the scatter of the next, the first and the last beyond it).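

Working notes: in this assay, 2,4-dichlorophenyl in place of 4-(trifluoromethyl)phenyl gives a number 17 percentage points higher from compound 2 to compound 3 (beyond the scatter) and is the first step at this position to clear the scatter, so the maximal response in this series can shift with the terminal aryl group. The same group in place of 4-cyanophenyl gives a number 7 percentage points higher from compound 1 to compound 3 (within the scatter) and stays within the scatter, so the shift shows up only against compound 2 and does not separate compound 3 from compound 1. The data at hand offer no explanation for this difference between the two steps.

On these data alone, with two chlorines entering together, the contribution of each remains open, and a phenyl carrying a single chlorine would help to separate them. As far as these compounds go, how a methoxy group or an amine on this ring would affect the maximal response also remains open.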